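The compounds below may be only part of what the source reports. "The series", "measured", "known", "first", "only" and "open" are said of these compounds alone.

Compound 1 `Brc1cccc2c1nnn2CC1CC1` — 70 nM
Compound 2 `CCn1nnc2c(Br)cccc21` — 2240 nM

In a functional assay on cells for positive allosteric modulation of metabotropic glutamate receptor 2 (Homo sapiens), read by fluorescence and calcium flux, with a stated time of 30 min (on this read-out lower numbers stand for an effect already at smaller amounts and higher numbers for an effect only at larger amounts of compound), compound 1 gives 70 nM, the lowest of the two numbers shown, while compound 2 gives 2240 nM. For the measured compounds named here, the one measured step between them, a 32-fold higher number from compound 1 to compound 2 (1.51 log units; beyond the scatter), concerns only the saturated chain carbon bound to the aromatic nitrogen.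

Compound 3 `FC(F)(F)c1cc(Br)c2nnn(CC3CC3)c2c1` keeps that cyclopropyl-bearing chain unchanged and instead carries trifluoromethyl in place of hydrogen on an aromatic carbon on the shared core. Going by the values given here, no measured step touches this six-membered aromatic ring, so the step of a 32-fold higher number from compound 1 to compound 2 (1.51 log units; beyond the scatter) says nothing directly about what a group placed there will do. Without a comparable example, the most defensible expectation is that the change from compound 1 to compound 3 brings no step beyond the usual scatter in this assay, though the direction could go either way, which makes the range wide.

Compound 3 is therefore estimated at 70 nM in this assay, with a range from 20 nM to 250 nM, which amounts to an expected step of no change at the digits printed from compound 1 to compound 3 (within the scatter).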

Compound 3, half-maximal effective concentration: 140 nM
Estimate against measurement, compound 3: 2.0-fold (0.30 log units) below; low and high end bracket the measured number.
By their numbers in this assay, from the lowest: compounds 1 and 3 (each within the scatter of the next); then compound 2.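

In this assay, for the compounds shown here, the swap of trifluoromethyl for hydrogen on an aromatic carbon, para to a fused ring and meta to a bromo group, gives a 2.0-fold higher number from compound 1 to compound 3 (0.30 log units; within the scatter) and thus offers the first measured look at the six-membered aromatic ring of the shared core. Going by these compounds alone, at this one position, a group of four heavy atoms can replace a hydrogen with a step that stays within the usual scatter, whereas the only earlier step, a 32-fold higher number from compound 1 to compound 2 (1.51 log units; beyond the scatter), lay beyond it and concerned the chain on the aromatic nitrogen. No accompanying measurement bears on what lies behind this result.

On these data alone, a single substituent cannot show how this aromatic carbon responds in general, so it remains open whether an amine, a carboxylic acid or a methoxy group there would also give a step within the scatter. Also open, as far as these compounds go, is what would follow from chlorine in place of the bromo group, or from a longer chain such as butyl in place of the cyclopropylmethyl group on the aromatic nitrogen.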